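The compounds below may be only part of what the source reports. "The series", "measured", "known", "first", "only" and "open" are said of these compounds alone.

Measured in an ADME assay on L929 cells (Mus musculus) for cytotoxicity, read by resazurin assay, with a stated time of 96 h; a higher number here means that more compound is tolerated, a lower number that less compound is tolerated:
- compound 1 `Cc1n[nH]c2c1[C@@H](c1ccc(OCc3ccccc3F)cc1)S[C@@H](C)C(=O)N2`: > 200000 nM
- compound 2 `Cc1ccccc1COc1ccc([C@H]2S[C@@H](C)C(=O)Nc3[nH]nc(C)c32)cc1`: 111000 nM

The value of compound 1 is a limit of the assay, not a number. Going by the values given here, compound 2, at 111000 nM, holds the only actual number in this assay.

Compound 3 `Cc1cccc(COc2ccc([C@H]3S[C@@H](C)C(=O)Nc4[nH]nc(C)c43)cc2)c1` carries 3-methylphenyl in place of 2-methylphenyl on a saturated chain carbon bound to an oxygen on an aromatic ring.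

Among the compounds with values here, the only measured step, an at least 1.8-fold lower number from compound 1 to compound 2 (0.25 log units; that floor lies within the scatter), is methyl in place of fluoro on an aromatic carbon, and it offers no firm guide. Within the data shown here, with only that step to go on, the expected change stays within the scatter, with no direction favoured: a 1.1-fold higher number from compound 2 to compound 3 (0.03 log units; within the scatter).

Compound 3 is estimated at 120000 nM, with an expected range of 60000 nM to 200000 nM.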

Compound 3, concentration lethal to 50% of the cells: 98900 nM
Compound 3: the middle estimate sits 1.2-fold (0.08 log units) above what was measured; the measured number falls inside the stated range.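

In this assay, 3-methylphenyl in place of 2-methylphenyl gives a 1.1-fold lower number from compound 2 to compound 3 (0.05 log units; within the scatter), so the two methylphenyl isomers cannot be told apart at this place. 3-methylphenyl in place of 2-fluorophenyl gives an at least 2.0-fold lower number from compound 1 to compound 3 (0.30 log units; that floor lies within the scatter). This step remains only a floor because compound 1 stands at a limit of the assay, not a number: the limit of > 200000 nM in this assay, at which 1 of the 3 values shown sits.

Still open, going by these compounds, is whether either methylphenyl group truly differs from 2-fluorophenyl. Also open, on these data alone, is how the number responds to an amine or a carboxylic acid on the phenyl group, or to a longer chain in place of the methyl.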